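Propyl for Hydrogen on a Weak Inhibitor

A few compounds are considered here, and "the series" means these few. Any claim that something is new, unique, unknown or untested is made for them only; others in the source may bear on it.

Compound 1, `CC(C)=NNc1nc(-c2cccc([N+](=O)[O-])c2)cs1`: 1160000 nM
Compound 2, `C=CCC/C(C)=N\Nc1nc(-c2cccc([N+](=O)[O-])c2)cs1`: 1210000 nM

Within the data shown here, in a functional assay, with a stated time of 30 min (a higher number here means a weaker inhibitor, a lower number a stronger inhibitor), compound 1 gives 1160000 nM, and compound 2 gives 1210000 nM; the two values lie within the scatter of each other, so neither compound stands apart on the numbers measured so far. Compound 3, `CCCC/C(C)=N\Nc1nc(-c2cccc([N+](=O)[O-])c2)cs1`, has not yet been measured. It differs from compound 1 by propyl in place of hydrogen on a saturated chain carbon bound to a carbon with a double bond to nitrogen. Among the measured compounds shown here, one measured step bears on this change: a 1.0-fold higher number from compound 1 to compound 2 (0.02 log units; within the scatter). That step placed another group at the very same position and the number did not move, so the propyl group is expected to behave alike, giving a step of a 1.0-fold higher number from compound 1 to compound 3 (0.01 log units; within the scatter), which is no change beyond the scatter. Compound 3 is therefore estimated to give 1200000 nM in this assay, with a likely range of 600000 nM to 2400000 nM.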

Compound 3, half-maximal inhibitory concentration: 1180000 nM
Beside the measured number, compound 3's estimate is 1.0-fold (0.01 log units) above it; the range from low to high includes it.
By their numbers in this assay, from the lowest: compounds 1, 3 and 2 (each within the scatter of the next).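

In this assay, a saturated propyl group at this position gives a 1.0-fold higher number from compound 1 to compound 3 (0.01 log units; within the scatter) and so leaves the number where it stood with hydrogen. Compound 2 had already shown this for a chain ending in a double bond, and now a 1.0-fold lower number from compound 2 to compound 3 (0.01 log units; within the scatter) shows that ethyl in place of vinyl makes no readable difference either, so for these two chains neither adding the chain nor the double bond in it separates the compounds. Nothing measured here explains this flat result.

Going by these compounds, both chains tested are made only of carbon and hydrogen, so it remains open whether an amine or a carboxylic acid at this position would shift the number. A longer chain or a ring placed here could also behave differently from propyl.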